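Aryl amine replacing the urea on the shared core

This account rests on a few compounds, and the source may have more. Where it says the series, first, only, none or still open, it means among the compounds named here.

Within the data shown here, in a functional assay on WI-38 VA13 cells (Homo sapiens) for cytotoxicity (a higher number here means that more compound is needed for the effect, a lower number that less compound is needed), compound 1 `NCCC(=O)Nc1nc2ccc(NC(=O)c3c(Cl)cccc3Cl)cc2s1` gives 5.3 ug/mL, and compound 2 `CCNC(=O)Nc1nc2ccc(NC(=O)c3c(Cl)cccc3Cl)cc2s1` gives 0.032 ug/mL, the lowest of the two numbers measured so far. Among the measured compounds shown here, the only measured step, a 170-fold lower number from compound 1 to compound 2 (2.22 log units; beyond the scatter), shows that what sits on this nitrogen can move the read-out by a large margin. Compound 3 `COc1ccccc1Nc1nc2ccc(NC(=O)c3c(Cl)cccc3Cl)cc2s1` differs from compound 2 at the same nitrogen: 2-methoxyphenyl in place of ethylcarbamoyl on a nitrogen on an aromatic ring. For the measured compounds named here, no measured pair mirrors this change; the one known step touches the same place but trades one chain for another, whereas here the chain leaves altogether and an aromatic ring enters. The expectation for compound 3 is therefore wide, leaning toward a higher number in this assay, estimated as a 16-fold higher number from compound 2 to compound 3 (1.19 log units; beyond the scatter). Compound 3 is expected to give about 0.5 ug/mL in this assay, within an estimated range from 0.03 ug/mL to 8 ug/mL.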

Compound 3, half-maximal effective concentration: > 7.2 ug/mL
Compound 3: a limit, no number; the forecaster's own chance of this, stated with the estimate: 10%; middle value at least 14-fold (1.15 log units) from the limit.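

Compound 3 carries a limit of the assay and not a number: the limit of > 7.2 ug/mL in this assay, at which 1 of the 3 values shown sits.

In this assay, the change from (ethylcarbamoyl)amino to (2-methoxyphenyl)amino gives an at least 220-fold higher number from compound 2 to compound 3 (2.35 log units; beyond the scatter), so the ethylcarbamoyl group alone holds the low number among the three compounds shown, and a second replacement on this nitrogen does not keep it. Against the (2-aminoethyl)carbonyl group, the reading is an at least 1.3-fold higher number from compound 1 to compound 3 (0.13 log units; that floor lies within the scatter), so the two replacements of the ethylcarbamoyl group cannot be put in order.

As far as these compounds go, whether an unsubstituted phenyl or a propylcarbamoyl group on this nitrogen would keep the low number stays open. Also open, from the compounds shown here alone, is how much of the large step belongs to the methoxy group and how much to the aromatic ring itself.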